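Lengthening a hydroxyalkyl chain on a triazole

The source may hold more compounds than are shown below. What is called first, only, known or untested is meant among the compounds shown, and "the series" means these compounds.

For the measured compounds named here, compound 3 `COc1nc2ccc(Br)cc2cc1C(c1ccccc1)n1cc(CCCO)nn1` is one of three compounds measured in an ADME assay on PANC-1 cells (Homo sapiens) for cytotoxicity, read by sulforhodamine B assay, with a stated time of 48 h, tested at 10 uM (on this read-out higher numbers stand for more inhibition at the one concentration tested (going by the name of the read-out) and lower numbers for less inhibition), where compound 3 gives 25.5%. Its companions are compound 1 `COc1nc2ccc(Br)cc2cc1C(c1ccccc1)n1cc(-c2ccc(Br)cc2)nn1`, which gives 10.4% in this assay, and compound 2 `CCCCCCCc1cn(C(c2ccccc2)c2cc3cc(Br)ccc3nc2OC)nn1`, which gives 16.6%. The difference a number 15.1 percentage points higher from compound 1 to compound 3 (beyond the scatter) lies beyond the scatter, whereas a number 8.9 percentage points higher from compound 2 to compound 3 (within the scatter) does not, so compound 3 stands apart from compound 1 only.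

Compound 4 `COc1nc2ccc(Br)cc2cc1C(c1ccccc1)n1cc(CCCCCO)nn1` differs from compound 3 by 2-hydroxyethyl in place of hydroxy on a saturated chain carbon, three bonds along the chain from an aromatic carbon. The step most like this one is a number 8.9 percentage points higher from compound 2 to compound 3 (within the scatter), where a hydroxy replaced a butyl on the same chain carbon and the number stayed within the scatter. The two aryl-to-chain steps, a number 6.2 percentage points higher from compound 1 to compound 2 (within the scatter) and a number 15.1 percentage points higher from compound 1 to compound 3 (beyond the scatter), change a different part of the molecule and say little here. Adding two carbons to the chain is therefore expected to leave the number within the scatter, an expected step of a number 2.5 percentage points lower from compound 3 to compound 4 (within the scatter). Compound 4 is estimated at 23%, with a range from 11% to 36%.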

Compound 4, a percentage reported as inhibition, at one concentration (the size of the read-out at that concentration, not a potency): 19.6%
Estimate against measurement, compound 4: 3.4 percentage points above; the range from low to high includes it.
By their numbers in this assay, from the lowest: compounds 1, 2, 4 and 3 (each within the scatter of the next, the first and the last beyond it).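

In this assay, the change from 3-hydroxypropyl to 5-hydroxypentyl gives a number 5.9 percentage points lower from compound 3 to compound 4 (within the scatter), so these two chain lengths cannot be told apart here. The 5-hydroxypentyl chain also cannot be told apart from heptyl, with a number 3 percentage points higher from compound 2 to compound 4 (within the scatter), or from 4-bromophenyl, with a number 9.2 percentage points higher from compound 1 to compound 4 (within the scatter), although 3-hydroxypropyl did stand apart from 4-bromophenyl, so carrying a hydroxy is not enough on its own to give that separation. No evidence at hand gives a reason for these numbers.

Still open, on these data alone, is whether a shorter chain such as hydroxymethyl, or a chain longer than 5-hydroxypentyl, would shift the number beyond the scatter. The same question stands for a chain ending in an amine or a carboxylic acid in place of the hydroxy.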